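The compounds below may be only part of what the source reports. "The series", "measured", "known", "first", "only" and "open" are said of these compounds alone.

Compound 1 `Cc1nc(C#Cc2cc(F)cc([N+](=O)[O-])c2)cs1` and compound 2 `Cc1cccc(C#Cc2cc(C#N)cc([N+](=O)[O-])c2)n1` both carry a nitro group on the carbon-only ring. In a functional assay on HEK293 cells for antagonist activity at metabotropic glutamate receptor 5 (Rattus norvegicus), read by calcium flux (a higher number here means a weaker inhibitor, a lower number a stronger inhibitor), compound 1 gives 0.61 nM, and in this assay compound 2 gives 3.68 nM, the higher of the two numbers, with the gap to compound 1 lying beyond the scatter. Compound 3 `Cc1cccc(C#Cc2cc(Cl)cc(C#N)c2)n1` is not yet measured; it differs from compound 2 by chloro in place of nitro on an aromatic carbon. Among the measured compounds shown here, no measured pair shows this swap, so the step from compound 2 to compound 3 is expected to stay within the scatter, as a 1.2-fold lower number from compound 2 to compound 3 (0.09 log units; within the scatter). Compound 3 is estimated at 3 nM, within 1 nM to 10 nM.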

Compound 3, half-maximal inhibitory concentration: 1.22 nM
Estimate against measurement, compound 3: 2.5-fold (0.39 log units) above; the measured number falls inside the stated range.
By their numbers in this assay, from the lowest: compounds 1 and 3 (each within the scatter of the next); then compound 2.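

Chloro in place of nitro, meta to a cyano group, gives a 3.0-fold lower number from compound 2 to compound 3 (0.48 log units; beyond the scatter) in this assay and so shows that a low number at this position does not require the nitro group. Chloro has 1 heavy atom and 0 hydrogen-bond acceptors, against 3 and 2 for nitro, so the nitro group's extra atoms and acceptors are not required here either. No available evidence explains the size of this step.

On these data alone, how other groups at this position, such as an amine or a methoxy group, would compare remains open. So does whether the same swap would behave alike on the core of compound 1.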